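Acid ceramidase series: swapping the saturated ring on the core

The source may hold more compounds than are shown below. What is called first, only, known or untested is meant among the compounds shown, and "the series" means these compounds.

Measured compounds:
compound 1 `CC(=O)N1CCC(c2ccc3c(c2)oc(=O)n3C(=O)NCCCCc2ccccc2)CC1` — 64 nM
compound 2 `CC(C)CNC(=O)n1c(=O)oc2cc(C3CCCN(C)C3)ccc21` — 1750 nM
compound 3 `CC(C)CNC(=O)n1c(=O)oc2cc(C3CCN(C)CC3)ccc21` — 166 nM

In an assay on HEK293 cells for inhibition of acid ceramidase (Homo sapiens), read by fluorescence, with stated times of 10 min and 3 h (on this read-out lower numbers stand for stronger inhibition and higher numbers for weaker inhibition), compound 1 gives the lowest number of the three, with compound 3 nearest and compound 2 furthest, both beyond the scatter. Compound 4 `CN1CCN(c2ccc3c(c2)oc(=O)n3C(=O)NCCCCc2ccccc2)CC1=O` differs from compound 1 in one place: 4-methyl-3-oxopiperazin-1-yl in place of 1-acetylpiperidin-4-yl on an aromatic carbon. For the measured compounds named here, the only measured step, an 11-fold lower number from compound 2 to compound 3 (1.02 log units; beyond the scatter), concerns where the saturated ring attaches to the core, not an exchange of the ring itself, so it gives no direct guidance here. Going by the values given here, no measured pair covers the change from compound 1 to compound 4. The expected step is therefore a 1.7-fold higher number from compound 1 to compound 4 (0.24 log units; within the scatter), with the number estimated to stay near that of compound 1. Compound 4 is expected to give 110 nM, within 35 nM to 400 nM.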

Compound 4, half-maximal inhibitory concentration: 92 nM
Compound 4: middle estimate off by 1.2-fold (0.08 log units), on the high side, within the range that was stated.
By their numbers in this assay, from the lowest: compounds 1, 4 and 3 (each within the scatter of the next, the first and the last beyond it); then compound 2.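

In this assay the change of ring itself can now be read: a 1.4-fold higher number from compound 1 to compound 4 (0.16 log units; within the scatter) shows that, at this aromatic carbon, 4-methyl-3-oxopiperazin-1-yl and 1-acetylpiperidin-4-yl cannot be told apart. The second hetero atom in the ring and the shift of the carbonyl into it leave the number within the scatter. Nothing measured explains this equivalence. Open, as far as these compounds go, is whether a ring with a free amine, such as unsubstituted piperazine, or a morpholine keeps the number at this carbon. Also open, from the compounds shown here alone, is whether the exchange holds with a carboxylic acid on the ring.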